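A sulfur linker in place of oxygen: one step forward

The source may hold more compounds than are shown below. What is called first, only, known or untested is meant among the compounds shown, and "the series" means these compounds.

Measured compounds:
compound 1, `COc1ccc(OC[C@@H]2CCc3cc([C@H]4CC[C@](N)(CO)C4)ccc3C2)cc1C(C)(C)C`, 53%
compound 2, `N[C@]1(CO)CC[C@H](c2ccc3c(c2)CC[C@@H](COc2ccc(F)cc2)C3)C1`, 74%
compound 3, `COc1ccc(OC[C@@H]2CCc3cc([C@H]4CC[C@](N)(CO)C4)ccc3C2)c(F)c1F`, 48%

In a functional assay on the whole organism (strain Lewis) with Rattus norvegicus as the target, with a stated time of 24 h, at a dose of 2 mg/kg by the oral route (a lower number here means less inhibition, a higher number more inhibition at the dose given (going by the name of the read-out)), compound 2 gives 74%, the highest of the three numbers, with compound 1 and compound 3 each more than the usual scatter below it. Compound 4, `COc1ccccc1SC[C@@H]1CCc2cc([C@H]3CC[C@](N)(CO)C3)ccc2C1`, has not yet been measured. It differs from compound 2 in one place: (2-methoxyphenyl)sulfanyl in place of 4-fluorophenoxy on a saturated chain carbon bound to a saturated ring carbon. Among the measured compounds shown here, the one measured step that bears on this kind of change is the swap of the aryl group on the same oxygen, a number 26 percentage points lower from compound 2 to compound 3 (beyond the scatter), which cut inhibition by a modest but real amount. Below compound 2 likewise sits compound 1, which also carries a methoxy-bearing aryl group in that region and gives 53%. Both measured neighbours of compound 2 lose inhibition when the 4-fluorophenyl is replaced, so a drop of similar size is expected for compound 4, a number 22 percentage points lower from compound 2 to compound 4 (beyond the scatter). Compound 4 is therefore estimated at 52%, within a range from 32% to 72%.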

Compound 4, a percentage reported as inhibition, in the whole organism at one dose (the size of the read-out at that dose, not a potency): 78%
Compound 4: the middle estimate sits 26 percentage points below what was measured, and the stated range ends below it.
By their numbers in this assay, from the lowest: compounds 3 and 1 (each within the scatter of the next); then compounds 2 and 4 (each within the scatter of the next).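

In this assay, the replacement at this position reads a number 4 percentage points higher from compound 2 to compound 4 (within the scatter), so a saturated chain carbon bound to a saturated ring carbon can carry (2-methoxyphenyl)sulfanyl in place of 4-fluorophenoxy with no step beyond the scatter. The earlier change at this site, a number 26 percentage points lower from compound 2 to compound 3 (beyond the scatter), swapped only the aryl group on the oxygen and came with a clear loss, so the new result shows that replacing 4-fluorophenoxy need not cost inhibition at this dose. Nothing available explains why these two changes end so differently.

This change alters the linking atom and the aryl group together, so the compounds shown cannot separate the part played by each. On these data alone, a pair carrying (4-fluorophenyl)sulfanyl and 2-methoxyphenoxy would tell them apart, and how an amine linker would fare here remains open.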